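Swapping phenoxy for pyridinyloxy: cytotoxicity on Vero cells

The source may report more compounds than this note shows. Statements on the series, on what has been measured and on what is new or still open speak of the compounds shown alone.

Compound 1 `CCc1nc2ccccc2n1CCCCOc1ccccc1` gives 21 uM in an ADME assay on Vero cells (Chlorocebus sabaeus) for cytotoxicity, read by luminescence, with a stated time of 2 days; on this read-out lower numbers stand for higher toxicity in this test and higher numbers for lower toxicity in this test. Of the two compounds with a numerical value, the other is compound 3 `CCc1nc2ccc(Cl)cc2n1CCCCOc1ccccc1`, which gives 25 uM; the step of a 1.2-fold higher number from compound 1 to compound 3 (0.08 log units; within the scatter) lies within the scatter. Compound 2 `Cc1nc2ccccc2n1CCCCOc1ccccc1` gives > 50 uM, which is a limit of the assay and not a number (the limit of > 50 uM in this assay, at which 1 of the 3 values shown sits). The step of an at least 2.3-fold higher number from compound 1 to compound 2 (0.37 log units; beyond the scatter) is at least modest. Compound 4 `CCc1nc2ccccc2n1CCCCOc1ccncc1` differs from compound 1 by pyridin-4-yl in place of phenyl on an oxygen on a saturated carbon. Neither measured step touches the phenoxy end of the chain, so neither bears directly on this change, and the two steps together span only a modest range. The expected step of a 1.5-fold higher number from compound 1 to compound 4 (0.18 log units; within the scatter) may therefore not exceed the scatter. Compound 4 is estimated at 32 uM, with a range from 14 uM to 70 uM.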

Compound 4, half-maximal toxic concentration: > 50 uM
Compound 4 was reported as a limit; the forecaster's own chance of this, stated with the estimate: 35%; at least 1.5-fold (0.19 log units) between middle value and limit.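

In this assay, for the compounds shown here, the phenoxy end of the chain proves to be a place where a single change can move the read-out: the step of an at least 2.3-fold higher number from compound 1 to compound 4 (0.37 log units; beyond the scatter) is the first one measured there, and it lies beyond the scatter. As far as these compounds go, compound 4 gives > 50 uM, which is a limit of the assay and not a number, so the full size of the step stays unknown. Values now gather at the top of the test's range: the limit of > 50 uM in this assay, at which 2 of the 4 values shown sit.

The compounds shown leave open whether pyridin-3-yl or pyridin-2-yl in place of phenyl would give a similar step. They also leave open whether an amine on the phenyl ring would do the same.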